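Aryl variation at the hydrazone carbon of the series

A few compounds are considered here, and "the series" means these few. Any claim that something is new, unique, unknown or untested is made for them only; others in the source may bear on it.

Compound 2 `CN(C)CCn1cnnc1-c1cc(Oc2ccc(NC(=O)N/N=C/c3ccccc3O[N+](=O)[O-])cc2F)ccn1` shares its core with compound 1 `COc1ccc(/C=N/NC(=O)Nc2ccc(Oc3ccnc(-c4nncn4CCN(C)C)c3)c(F)c2)c(OC)c1` and differs from it only in the aryl group on the carbon with a double bond to nitrogen. In a functional assay on U-87MG ATCC cells (Homo sapiens) for cytotoxicity, read by MTT assay, with a stated time of 72 h (a higher number here means a weaker inhibitor, a lower number a stronger inhibitor), compound 1 gives 12600 nM, and compound 2 gives 7150 nM; the move is a 1.8-fold lower number from compound 1 to compound 2 (0.25 log units; within the scatter). Among the two numbers shown, compound 2 holds the lower one, with compound 1 the only neighbour and within the scatter of it. For the measured compounds named here, compound 3 `Cn1ncnc1-c1cc(Oc2ccc(NC(=O)N/N=C/c3ccccc3)cc2F)ccn1` gives only a limit in this assay, > 100000 nM, and is noted as such (the limit of > 100000 nM in this assay, at which 1 of the 3 values shown sits); it differs from compound 2 in two places, so no single step connects them.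

Compound 4 `CN(C)CCn1cnnc1-c1cc(Oc2ccc(NC(=O)N/N=C/c3c(O)ccc4ccccc34)cc2F)ccn1` carries the change (2-hydroxynaphthalen-1-yl in place of 2-(nitrooxy)phenyl on a carbon with a double bond to nitrogen). Going by the values given here, the one measured step at this carbon, from compound 1 to compound 2, stayed within the scatter, so another aryl swap at the same position is expected to move the number little, in no firm direction. Compound 4 is expected to give 7000 nM in this assay, within 2500 nM to 20000 nM. The estimated step is a 1.0-fold lower number from compound 2 to compound 4 (0.01 log units; within the scatter) in this assay.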

Compound 4, half-maximal inhibitory concentration: 620 nM
Estimate against measurement, compound 4: 11-fold (1.05 log units) above; the whole stated range lies above it.
By their numbers in this assay, from the lowest: compound 4; then compounds 2 and 1 (each within the scatter of the next). At a limit, above all of these: compound 3.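

The aryl group on the carbon with a double bond to nitrogen proves able to shift the number in this assay: 2-hydroxynaphthalen-1-yl gives a 12-fold lower number from compound 2 to compound 4 (1.06 log units; beyond the scatter), and against 2,4-dimethoxyphenyl it gives a 20-fold lower number from compound 1 to compound 4 (1.31 log units; beyond the scatter). Compounds 1 and 2 lie within the scatter of each other, so the two single-ring aryl groups did not separate, whereas compound 4 separates from both. The change from 2-(nitrooxy)phenyl replaces one six-membered aromatic ring with 2 and 0 hydrogen-bond donors with 1, so ring count and donor count change together.

Whether the hydroxyl or the second ring accounts for the step stays open, and a plain naphthalen-1-yl or a 2-aminonaphthalen-1-yl at this carbon would separate the two. No measured property given here bears on the step.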